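Urea series: ethyl returns to methyl, chlorine enters

This account rests on a few compounds, and the source may have more. Where it says the series, first, only, none or still open, it means among the compounds named here.

Three compounds of the series have numbers in an assay on IM-9 cells for binding affinity to Substance-P receptor (Homo sapiens); a lower number here means a stronger inhibitor, a higher number a weaker inhibitor. Compound 1 `CN(Cc1cc(C(F)(F)F)cc(C(F)(F)F)c1)C(=O)Cc1c(-c2ccccc2)c2ccccc2c(=O)n1C` gives 68 nM. Compound 2 `Cc1cc2c(-c3ccccc3)c(NC(=O)N(C)Cc3ccccc3)n(C)c(=O)c2cc1C` gives 16 nM. Compound 3 `CCN(Cc1ccccc1)C(=O)Nc1c(-c2ccccc2)c2cc(C)c(C)cc2c(=O)n1C` gives 66 nM, the second highest number of the three: compound 1 stands within the scatter of it, while compound 2 stands beyond the scatter, lower.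

One single-point step is known: a 4.1-fold higher number from compound 2 to compound 3 (0.62 log units; beyond the scatter). Compound 4 `Cc1cc2c(-c3ccccc3)c(NC(=O)N(C)Cc3ccccc3Cl)n(C)c(=O)c2cc1C` is not yet measured. Against compound 3 the change is a group of 10 heavy atoms (8 carbon, 1 nitrogen, 1 chlorine; one six-membered aromatic ring of carbon only) in place of a group of 10 heavy atoms (9 carbon, 1 nitrogen; one six-membered aromatic ring of carbon only), on a carbonyl carbon. Read through the structures, this folds two alterations into one: the ethyl of the benzyl(ethyl)amino group of compound 3 gives way to the methyl seen in compound 2, and the entering group carries a chlorine that the leaving group does not. The first part is the reverse of the step from compound 2 to compound 3, modest but beyond the scatter, and by itself would bring the number back near that of compound 2. Within the data shown here, no measured step speaks to the chlorine, so its contribution is unknown and widens the range. A lower number than compound 3 is therefore expected, a 3.0-fold lower number from compound 3 to compound 4 (0.48 log units; beyond the scatter). Compound 4 is estimated at 22 nM, with a range from 7 nM to 70 nM.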

Compound 4, half-maximal inhibitory concentration: 4.2 nM
Estimate against measurement, compound 4: 5.2-fold (0.72 log units) above; the whole stated range lies above it.
By their numbers in this assay, from the lowest: compound 4; then compound 2; then compounds 3 and 1 (each within the scatter of the next).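

In this assay, among these compounds, the aromatic ring of the benzyl part responds to substitution: chloro in place of hydrogen on an aromatic carbon gives a 3.8-fold lower number from compound 2 to compound 4 (0.58 log units; beyond the scatter), the first measured single change on that ring. The exchange on the carbonyl carbon gives a 16-fold lower number from compound 3 to compound 4 (1.20 log units; beyond the scatter), and the return from ethyl to methyl accounts for only part of this, as the step in the opposite direction is a 4.1-fold higher number from compound 2 to compound 3 (0.62 log units; beyond the scatter), with the chloro step supplying the rest. No measurement here accounts for the gain from chloro.

Still open, from the compounds shown here alone, is whether bromo or methoxy on the same aromatic carbon would shift the number as chloro does, and whether chloro on another carbon of that ring would do the same. It is also unknown whether the chloro step would hold with ethyl rather than methyl on the amide-type nitrogen.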